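Working notes on the aryl swap from compound 1 to compound 4

The source may hold more compounds than are shown below. What is called first, only, known or untested is meant among the compounds shown, and "the series" means these compounds.

Measured compounds:
compound 1 `COc1ccc(/C=N/NC(=O)Nc2ccc(Oc3ccnc(-c4nncn4CCN(C)C)c3)c(F)c2)c(OC)c1` — 12600 nM
compound 2 `CN(C)CCn1cnnc1-c1cc(Oc2ccc(NC(=O)N/N=C/c3ccccc3)cc2F)ccn1` — 2250 nM
compound 3 `CN(C)CCn1cnnc1-c1cc(Oc2ccc(NC(=O)N/N=C/c3ccc(F)cc3)cc2F)ccn1` — 2310 nM

In a functional assay on U-87MG ATCC cells (Homo sapiens) for cytotoxicity, read by MTT assay, with a stated time of 72 h (a lower number here means a stronger inhibitor, a higher number a weaker inhibitor), compound 1 gives 12600 nM, the highest of the three numbers; the nearest is compound 3 with 2310 nM and the furthest compound 2 with 2250 nM. Compound 4 `CN(C)CCn1cnnc1-c1cc(Oc2ccc(NC(=O)N/N=C/c3ccc(O)c(O)c3)cc2F)ccn1` differs from compound 1 by 3,4-dihydroxyphenyl in place of 2,4-dimethoxyphenyl on a carbon with a double bond to nitrogen.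

For the measured compounds named here, two measured steps bear on this change, since both also remove the 2,4-dimethoxyphenyl from compound 1: a 5.6-fold lower number from compound 1 to compound 2 (0.75 log units; beyond the scatter) and a 5.5-fold lower number from compound 1 to compound 3 (0.74 log units; beyond the scatter). The third step, a 1.0-fold higher number from compound 2 to compound 3 (0.01 log units; within the scatter), shows that a single fluoro on the entering phenyl changes nothing beyond the scatter. Going by the values given here, no measured pair carries a hydroxyl on this ring, so the effect of the two hydroxyls of the 3,4-dihydroxyphenyl is untested. The expectation is therefore a lower number for compound 4 than for compound 1, in the direction of both removal steps, but with wide uncertainty about its size. Compound 4 is estimated at 4500 nM in this assay, range 1500 nM to 14000 nM, which is expected to amount to a 2.8-fold lower number from compound 1 to compound 4 (0.45 log units; beyond the scatter).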

Compound 4, half-maximal inhibitory concentration: > 100000 nM
Compound 4: a limit, no number (the forecaster's own chance of this, stated with the estimate: 5%); at least 22-fold (1.34 log units) between middle value and limit.
By their numbers in this assay, from the lowest: compounds 2 and 3 (each within the scatter of the next); then compound 1. At a limit, above all of these: compound 4.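

In this assay compound 4 gives only a limit, not a number: the limit of > 100000 nM in this assay, at which 1 of the 4 values shown sits.

Leaving the 2,4-dimethoxyphenyl on the carbon with a double bond to nitrogen therefore does not by itself give a lower number, since the change to 3,4-dihydroxyphenyl reverses the direction of the earlier steps, with an at least 7.9-fold higher number from compound 1 to compound 4 (0.89 log units; beyond the scatter). Against the phenyl and the 4-fluorophenyl the same entering group gives an at least 44-fold higher number from compound 2 to compound 4 (1.64 log units; beyond the scatter) and an at least 43-fold higher number from compound 3 to compound 4 (1.63 log units; beyond the scatter), whereas a single fluoro on that ring had changed nothing beyond the scatter.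

The compounds shown leave open whether one hydroxyl, as in a 4-hydroxyphenyl, is enough for this step or whether both are required. They also leave open whether a 3,4-dimethoxyphenyl, which carries methyl groups on those same oxygens, would return to the range of compound 2 and compound 3.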